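The source may report more compounds than this note shows. Statements on the series, on what has been measured and on what is new or still open speak of the compounds shown alone.

Two compounds of the shared core are known, and only one of them carries a number. Compound 1 `N#Cc1ccn2c(-c3ccccc3)c(-c3ccccc3)c(C(O)C3CCCCC3)c2c1` is reported in an assay for inhibition of Polyunsaturated fatty acid lipoxygenase ALOX15 (Oryctolagus cuniculus) (a lower number here means a stronger inhibitor, a higher number a weaker inhibitor), as "not determined" (no result reported), with no result behind it. Going by the values given here, compound 2 `N#Cc1ccn2c(-c3ccccc3)c(-c3ccccc3)c(Cc3ccccc3)c2c1` is the one with a value: in this assay compound 2 gives 46000 nM, a weak inhibition, and since compound 1 was reported without a value, compound 2 stands alone rather than in any order. Compound 3 `N#Cc1ccn2c(-c3ccccc3)c(-c3ccccc3)c(CO)c2c1` has not yet been measured. It differs from compound 2 in one place: hydroxy in place of phenyl on a saturated chain carbon bound to an aromatic carbon. Read one bond further out, the change is benzyl to hydroxymethyl, so the saturated chain carbon bound to an aromatic carbon now carries a hydroxy group in place of a phenyl. Among the compounds with values here, no measured pair shows what such a change does on this core, so the size of the step is uncertain. The expectation is a small step, a 1.5-fold higher number from compound 2 to compound 3 (0.18 log units; within the scatter), toward a weaker inhibitor, barely beyond the usual scatter if at all. For compound 3 the estimate in this assay is 70000 nM, in a range from 18000 nM to 250000 nM, with a real chance that only a limit is reported.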

Compound 3, half-maximal inhibitory concentration: 34000 nM
The estimate for compound 3 lay 2.1-fold (0.31 log units) above the measured number; the measured number falls inside the stated range.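

In this assay, exchanging benzyl for hydroxymethyl gives a 1.4-fold lower number from compound 2 to compound 3 (0.13 log units; within the scatter), so this single step does not separate the two compounds. The exchange is not a small one on paper: a phenyl with its 6 heavy atoms leaves the saturated chain carbon bound to an aromatic carbon, and a hydroxy with 1 hydrogen-bond donor and 1 hydrogen-bond acceptor enters, yet the weak inhibition of compound 2 is retained in compound 3, showing that this phenyl is not required for that level of inhibition on the shared core. No supporting evidence is available to explain why the exchange leaves the reading within the scatter.

This one pair cannot show whether the position is generally tolerant or whether these two quite different groups merely happen to give similar numbers. An amine, a carboxylic acid or a longer chain at this carbon could test whether any group placed there moves the number beyond the scatter, and whether stronger inhibition can be reached from this position at all.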